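Amide substituent change on a sulfonamide-bearing core

The source may hold more compounds than are shown below. What is called first, only, known or untested is meant among the compounds shown, and "the series" means these compounds.

Measured so far:
- compound 1, `CC(C)(C)NS(=O)(=O)c1ncc(-c2sc(C(=O)N[C@H]3C[C@H](C(=O)O)C3)nc2CC2CCCCC2)c2ccccc12`: 1.02 h
- compound 2, `CC(C)(C)NS(=O)(=O)c1ccc(-c2sc(C(=O)N3CC4(C3)CS(=O)(=O)C4)nc2CC2CCCCC2)c(Cl)c1Cl`: 0.917 h

In an ADME assay on microsomes (Rattus norvegicus) for metabolic stability (a higher number here means that the compound lasts longer, a lower number that the compound disappears faster), compound 1 gives 1.02 h, and compound 2 gives 0.917 h; the two values lie within the scatter of each other, so neither stands apart. Compound 3, `CC(C)(O)CNC(=O)c1nc(CC2CCCCC2)c(-c2cnc(S(=O)(=O)NC(C)(C)C)c3ccccc23)s1`, has not yet been measured in this assay. It differs from compound 1 by 2-hydroxy-2-methylpropyl in place of 3-carboxycyclobutyl on an amide-type nitrogen. For the measured compounds named here, no step between measured compounds covers such a change, so the size of the step is uncertain; the expectation is for no step beyond the scatter, in either direction, from compound 1 to compound 3, a 1.1-fold lower number from compound 1 to compound 3 (0.05 log units; within the scatter). Compound 3 is therefore estimated at 0.9 h, with a range from 0.4 h to 2 h.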

Compound 3, half-life in the Rattus norvegicus assay: 0.0867 h
Compound 3: middle estimate off by 10-fold (1.02 log units), on the high side, outside the stated range (below it).
By their numbers in the Rattus norvegicus assay, from the lowest: compound 3; then compounds 2 and 1 (each within the scatter of the next).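

In the Rattus norvegicus assay, the group on the amide-type nitrogen turns out to matter greatly: 2-hydroxy-2-methylpropyl in place of 3-carboxycyclobutyl gives a 12-fold lower number from compound 1 to compound 3 (1.07 log units; beyond the scatter). In a physicochemical assay for solubility, read by HPLC, in phosphate buffer, measured as thermodynamic solubility, with a stated time of 5 days, at pH 7, tested at 10 mM (a higher number here means a more soluble compound, a lower number a less soluble compound), the same change gives an at least 3.2-fold lower number from compound 1 to compound 3 (0.51 log units; beyond the scatter). In the physicochemical assay compound 1 gives 13000 nM as a measured number. In the physicochemical assay compound 3 gives < 4000 nM as a limit of the assay and not a number: the limit of < 4000 nM in the physicochemical assay, at which 1 of the 2 values shown sits.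

With only this one replacement shown, the data cannot separate the part played by the carboxylic acid from that of the cyclobutyl ring. Still open, from the compounds shown here alone, is how a carboxylic acid on an open chain, or an amine on the cyclobutyl ring, would fare in the Rattus norvegicus assay.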